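Cytotoxicity notes: three limits measured, one compound open

The compounds below may be only part of what the source reports. "The series", "measured", "known", "first", "only" and "open" are said of these compounds alone.

Measured compounds and values:
compound 1 `Nc1cc(-c2ccccc2)ccc1Cn1cncc1CNc1ccc(Cl)c(-c2ccccc2)c1` — in a toxicity assay on NIH3T3 cells (Mus musculus) for cytotoxicity, read by resazurin assay (a higher number here means that more compound is needed for the effect, a lower number that less compound is needed), compound 1 gives > 1000 nM, which is a limit of the assay and not a number.
compound 2 `COC(=O)c1ccc(NCc2cncn2Cc2cccc(C#N)c2)cc1-c1ccccc1` — in this assay compound 2 gives > 10000 nM, also a limit.
compound 3 `c1ccc(Cn2cncc2CNc2cccc(-c3cccnc3)c2)cc1` — in this assay compound 3 gives > 1000 nM, again a limit.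

Compound 2 stands at a limit in this assay; no number is known for it, only that the assay reported (the limit of > 10000 nM in this assay, at which 1 of the 3 values shown sits). The other two compounds sit at the limit of > 1000 nM in this assay, at which 2 of the 3 values shown sit. Going by the values given here, no two of the measured compounds differ in a single place, so no measured step exists. What the three values show together is simply that none of the compounds reached a half-maximal effective concentration within the range tested.

Compound 4 `COC(=O)c1ccc(NCc2cncn2Cc2ccccc2[N+](=O)[O-])cc1-c1ccccc1` has not yet been measured in this assay. It differs from compound 2 by 2-nitrophenyl in place of 3-cyanophenyl on a saturated chain carbon bound to an aromatic nitrogen. The change is confined to the group on the saturated chain carbon bound to an aromatic nitrogen; the rest of compound 2 is kept unchanged.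

Among the compounds with values here, with no measured step to lean on and compound 2 already at a limit, the step from compound 2 to compound 4 is expected to be a step that the limit leaves unreadable from compound 2 to compound 4, nothing beyond the scatter. Compound 4 is expected at 15000 nM, within 4000 nM to 60000 nM, and most likely the assay reports a limit again rather than a number.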

Compound 4, half-maximal effective concentration: 10000 nM
Compound 4: the middle estimate sits 1.5-fold (0.18 log units) above what was measured, within the range that was stated.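

In this assay compound 4 gives 10000 nM, the only value among the compounds shown that is a number and not a limit, so a read-out inside the tested range is now known for a compound changed at this position. Compound 2 gives > 10000 nM, which is a limit. Placing 2-nitrophenyl in place of 3-cyanophenyl on a saturated chain carbon bound to an aromatic nitrogen gives a number no higher from compound 2 to compound 4 (the limit leaves the size open), and the size of this step cannot be read because compound 2 stands at a limit: the limit of > 10000 nM in this assay, at which 1 of the 4 values shown sits.

The compounds shown do not separate the effect of the nitro group from that of its place on the ring, and a single change of this kind sets no trend for the position. From the compounds shown here alone, how 3-nitrophenyl, or a carboxylic acid or a longer chain in place of the 2-nitrophenyl, would read in this assay stays open, and a further number at this position would be needed before any step here can be sized.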